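The source may report more compounds than this note shows. Statements on the series, on what has been measured and on what is new or still open speak of the compounds shown alone.

Working notes on the series. The shared core is held fixed and only the group on the saturated ring carbon of the piperidine-like ring changes. Going by the values given here, compound 1 `CN(C1CCN(CCCc2c[nH]c3ccc(-n4cnnc4)cc23)CC1)S(=O)(=O)c1ccccc1` carries the methyl(phenylsulfonyl)amino group there; in an assay on CHO cells for displacement of a labelled ligand from 5-hydroxytryptamine receptor 1D (Homo sapiens) (a higher number here means a weaker inhibitor, a lower number a stronger inhibitor), compound 1 gives 1.5 nM, the lowest of the two numbers so far. Compound 2 `CN(Cc1ccc(S(C)(=O)=O)cc1)C1CCN(CCCc2c[nH]c3ccc(-n4cnnc4)cc23)CC1` in this assay gives 18 nM; the step of a 12-fold higher number from compound 1 to compound 2 (1.08 log units; beyond the scatter) shows that replacing the sulfonyl-linked group costs affinity. Compound 3 `c1ccc2c(c1)CCC2NCC1CCN(CCCc2c[nH]c3ccc(-n4cnnc4)cc23)CC1` is not yet measured. The change from compound 1 is ((2,3-dihydro-1H-inden-1-yl)amino)methyl in place of methyl(phenylsulfonyl)amino on a saturated ring carbon. Among the compounds with values here, no measured step matches this change; the only step available, from compound 1 to compound 2, removes the same sulfonamide and loses clearly, so a comparable loss is the working expectation. The expected step is an 8.0-fold higher number from compound 1 to compound 3 (0.90 log units; beyond the scatter). For compound 3 the estimate in this assay is 12 nM, within a range of 2.5 nM to 60 nM.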

Compound 3, half-maximal inhibitory concentration: 1.1 nM
The estimate for compound 3 lay 11-fold (1.04 log units) above the measured number, and the stated range ends above it.
By their numbers in this assay, from the lowest: compounds 3 and 1 (each within the scatter of the next); then compound 2.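

In this assay the step of a 1.4-fold lower number from compound 1 to compound 3 (0.13 log units; within the scatter) shows that a sulfonamide is not needed on this saturated ring carbon: ((2,3-dihydro-1H-inden-1-yl)amino)methyl, which holds no sulfur or oxygen, matches methyl(phenylsulfonyl)amino within the scatter. The step of a 12-fold higher number from compound 1 to compound 2 (1.08 log units; beyond the scatter) therefore cannot stand as a general cost of replacing the sulfonyl-linked group, as compound 3 goes against that reading. Nothing measured bears on why compound 3 keeps the number of compound 1 while compound 2 does not.

Open, on these data alone, is whether the amine hydrogen of the entering group matters, which a tertiary methylamino link in place of the secondary amine would test. Also open, as far as these compounds go, is whether the five-membered non-aromatic ring matters, which a simple benzylamino group would test.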